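This account rests on a few compounds, and the source may have more. Where it says the series, first, only, none or still open, it means among the compounds named here.

Measured in an ADME assay on LLC-PK11 cells (Sus scrofa) for cytotoxicity, read by neutral red uptake, with a stated time of 48 h; a lower number here means a stronger inhibitor, a higher number a weaker inhibitor:
- compound 1 `Cc1cc(NCCCCCCNc2ccnc3cc(Cl)ccc23)nc(N2CCN(C)CC2)n1` gives 7200 nM
- compound 2 `Cc1cc(Cl)nc(NCCCCCCNc2ccnc3cc(Cl)ccc23)n1` gives 24000 nM
- compound 3 `Cc1cc(Cl)nc(NCCNc2ccnc3cc(Cl)ccc23)n1` gives 42300 nM

Compound 1 has the lowest number of the three, and its gaps to compound 2 and compound 3 both lie beyond the scatter. For the measured compounds named here, no two measured compounds differ in one place only, so the series gives no direct measure of any single change.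

Compound 4 `Cc1cc(NCCCCCCNc2ccnc3cc(Cl)ccc23)nc(N2CCCCC2)n1` is still to be measured in this assay. Compared with compound 1, it has piperidin-1-yl in place of 4-methylpiperazin-1-yl on an aromatic carbon, between two ring nitrogen atoms (piperidin-1-yl in place of 4-methylpiperazin-1-yl on an aromatic carbon). Going by the values given here, the measured compounds offer no precedent for this swap, so the expectation is anchored on compound 1 at 7200 nM. No step beyond the scatter is expected, with a slight lean towards a lower number. The estimated step runs a 1.2-fold lower number from compound 1 to compound 4 (0.08 log units; within the scatter). Compound 4 is expected at 6000 nM, with an estimated range from 2500 nM to 16000 nM.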

Compound 4, half-maximal inhibitory concentration: 6300 nM
For compound 4 the middle estimate is 1.1-fold (0.02 log units) below the measured one, within the range that was stated.
By their numbers in this assay, from the lowest: compounds 4 and 1 (each within the scatter of the next); then compounds 2 and 3 (each within the scatter of the next).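

In this assay, the aromatic carbon between two ring nitrogen atoms now has its first comparison in which only one place differs: piperidin-1-yl in place of 4-methylpiperazin-1-yl gives a 1.1-fold lower number from compound 1 to compound 4 (0.06 log units; within the scatter). For this pair, removing the ring hetero atom and the methyl group of the 4-methylpiperazin-1-yl substituent leaves the number within the scatter, so the two rings are not separated here. No measured property is available to explain this result.

From the compounds shown here alone, whether a small open-chain amine such as dimethylamino, or a ring bearing a carboxylic acid, would move the number beyond the scatter at this position remains open. Going by these compounds, it is also open whether the same swap would read alike on a shorter chain between the two ring systems.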